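The compounds below may be only part of what the source reports. "The series", "measured", "known", "first", "only" and "open" are said of these compounds alone.

Compound 1 `N/C(=N\O)c1cn([C@@H]2O[C@H](CO)[C@@H](O)[C@H]2O)c2nnnc(N)c12` carries a nitrogen-and-oxygen-bearing group on the five-membered ring of its fused two-ring core, with a sugar attached through the ring nitrogen. In a functional assay on KB cells (Homo sapiens) for inhibition (a lower number here means a stronger inhibitor, a higher number a weaker inhibitor), compound 1 gives 1500 nM, the lowest number among the values at hand. Compound 2 `Cc1ccc(C(=O)OC[C@H]2O[C@@H](n3cc(C(N)=O)c(C(N)=O)c3N)C[C@@H]2OC(=O)c2ccc(C)cc2)cc1`, built on another core with another sugar and two ester groups, gives in this assay 100000 nM, a gap from compound 1 that lies well beyond the usual scatter. Compound 3 `NC(=O)c1cn([C@@H]2O[C@H](COC(=O)c3ccccc3)[C@@H](OC(=O)c3ccccc3)[C@H]2OC(=O)c2ccccc2)c(N)c1C(N)=O` is a triply esterified relative of compound 2. In this assay compound 3 reaches only a limit, > 10000 nM, so no number is known for it; it sits at the limit of > 10000 nM in this assay, at which 1 of the 3 values shown sits.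

Compound 4 `COC(=N)c1cn([C@@H]2O[C@H](CO)[C@@H](O)[C@H]2O)c2nnnc(N)c12` differs from compound 1 in one place: a group of 4 heavy atoms (2 carbon, 1 nitrogen, 1 oxygen; no ring) in place of a group of 4 heavy atoms (1 carbon, 2 nitrogen, 1 oxygen; no ring), on an aromatic carbon. Among the compounds with values here, no measured pair in this set differs in a single place, so the size of such a step has no direct anchor here. The change keeps the group small and trades one hydrogen-bond donor for a carbon, and the author expects a step toward a somewhat higher number, a 2.0-fold higher number from compound 1 to compound 4 (0.30 log units; within the scatter), though one that may fall within the scatter. Compound 4 is therefore estimated to give 3000 nM in this assay, with a range from 700 nM to 15000 nM.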

Compound 4, half-maximal inhibitory concentration: 20000 nM
Compound 4: middle estimate off by 6.7-fold (0.82 log units), on the low side, and the stated range ends below it.
By their numbers in this assay, from the lowest: compound 1; then compound 4; then compound 2.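

In this assay, within the data shown here, the change on this aromatic carbon gives a 13-fold higher number from compound 1 to compound 4 (1.12 log units; beyond the scatter), the first step in the set between compounds that differ in one place, and it lies beyond the scatter. The leaving and entering groups have the same count of heavy atoms, neither has a ring, and each has 1 double bond outside aromatic rings and no net charge, so this position separates two groups of equal size; the entering group has a carbon in place of a nitrogen and 1 hydrogen-bond donor in place of 2. The information at hand offers no reason for the size of this step.

A single pair cannot show whether the change in donor count or the exchange of the whole group goes with this step. As far as these compounds go, how a nitrile, a carboxylic acid or a longer chain on this same aromatic carbon of the shared core would stand against compound 1 in this assay remains open.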